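The source may report more compounds than this note shows. Statements on the series, on what has been measured and on what is new or still open speak of the compounds shown alone.

Compound 1 `Cn1c(-c2ccccc2)cnc1NC(=O)c1ccc(F)cc1` is examined in a toxicity assay on THP-1 cells (Homo sapiens) for inhibition; a lower number here means that less compound is tolerated, a higher number that more compound is tolerated; compound 1 gives > 100000 nM, which is a limit of the assay rather than a number. Compound 2 `Cc1ccccc1C(=O)Nc1ncc(-c2ccccc2)n1C` gives > 100000 nM, likewise a limit. Compound 3 `Cn1c(-c2ccccc2)cnc1NC(=O)c1ccccc1Cl` gives > 50000 nM, again a limit. The steps a step that the two limits leave unreadable from compound 1 to compound 2, a step that the two limits leave unreadable from compound 1 to compound 3 and a step that the two limits leave unreadable from compound 2 to compound 3 are thus unreadable in size; the series shows only the two limits the limit of > 100000 nM in this assay, at which 2 of the 3 values shown sit, and (the limit of > 50000 nM in this assay, at which 1 of the 3 values shown sits). Compound 4 `Cn1c(-c2cccc(C#N)c2)cnc1NC(=O)c1ccc(F)cc1` differs from compound 1 by cyano in place of hydrogen on an aromatic carbon, phenyl to 3-cyanophenyl, a change at a different part of the molecule than the measured steps, none of which bears on it. For compound 4 the expected value is 100000 nM, with a range of 30000 nM to 300000 nM. The estimated step is a number no higher from compound 1 to compound 4 (the limit leaves the size open), most likely again reported as a limit.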

Compound 4, half-maximal cytotoxic concentration: > 100000 nM
Compound 4 was reported as a limit; the forecaster's own chance of this, stated with the estimate: 80%; the middle value lies on the limit itself.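

Compound 4 gives > 100000 nM, a limit of the assay. With compound 1 also reported as a limit, the step between compound 1 and compound 4 cannot be read. The compounds shown leave open whether cyano in place of hydrogen shifts the value in this assay at all.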